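Swapping the benzylic heteroaryl for a nitrophenyl ring

The compounds below may be only part of what the source reports. "The series", "measured", "known", "first", "only" and "open" are said of these compounds alone.

Compound 1 `Cc1cc(Nc2nn(Cc3cccnc3)c(=O)c3ccccc23)n[nH]1` gives 13400 nM in a functional assay on MCF7 cells (Homo sapiens) for cytotoxicity; on this read-out lower numbers stand for stronger inhibition and higher numbers for weaker inhibition. Compound 2 `Cc1cc(Nc2nn(Cc3csc(C)n3)c(=O)c3ccccc23)n[nH]1` gives > 30000 nM in this assay, and that figure is a limit of the assay rather than a number.

Compound 2 therefore stands at the weak end of what has been measured, as the limit of > 30000 nM in this assay, at which 1 of the 2 values shown sits, shows. The step from compound 1 to compound 2, an at least 2.2-fold higher number from compound 1 to compound 2 (0.35 log units; beyond the scatter), is the only measured one, and it moved the number upward when 2-methyl-1,3-thiazol-4-yl replaced pyridin-3-yl.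

Compound 3 `Cc1cc(Nc2nn(Cc3ccc([N+](=O)[O-])cc3)c(=O)c3ccccc23)n[nH]1` differs from compound 2 by 4-nitrophenyl in place of 2-methyl-1,3-thiazol-4-yl on a saturated chain carbon bound to an aromatic nitrogen. Going by the values given here, no measured step involves 4-nitrophenyl, so the direction rests on little. Because compound 2 sits at the limit (the limit of > 30000 nM in this assay, at which 1 of the 2 values shown sits), a return toward the range of compound 1 is the expected outcome, with an at least 1.5-fold lower number from compound 2 to compound 3 (0.17 log units; that floor lies within the scatter) as the estimated step. Compound 3 is expected to give about 20000 nM in this assay, within 7000 nM to 60000 nM.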

Compound 3, half-maximal inhibitory concentration: > 30000 nM
Compound 3 gave a limit, no number; the forecaster's own chance of this, stated with the estimate: 45%; middle value at least 1.5-fold (0.17 log units) from the limit.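

With 4-nitrophenyl on a saturated chain carbon bound to an aromatic nitrogen, a second group reaches the weak end of this assay, so that end is not particular to 2-methyl-1,3-thiazol-4-yl. Replacing pyridin-3-yl with 4-nitrophenyl gives an at least 2.2-fold higher number from compound 1 to compound 3 (0.35 log units; beyond the scatter), which leaves pyridin-3-yl as the only group shown at this place with a readable number. Compound 3 gives a limit of the assay rather than a number, like compound 2, so the step between them cannot be read: the limit of > 30000 nM in this assay, at which 2 of the 3 values shown sit.

It remains open whether any group at this place can bring the number below that of compound 1, since only three groups are shown. On these data alone, how an amine, a carboxylic acid or a longer chain would behave at this place also stays unknown.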